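The source may hold more compounds than are shown below. What is called first, only, known or untested is meant among the compounds shown, and "the series" means these compounds.

Three compounds share one core. Compound 1 (`C#CCCCCOc1ncc(-c2ccccc2OC)n1C`) was run in a functional assay on U-373MG ATCC cells (Homo sapiens) for inhibition, read by colorimetric assay and MTT assay, with a stated time of 72 h (a lower number here means a stronger inhibitor, a higher number a weaker inhibitor), but compound 1 gives "not determined" (no result reported), so it adds no number to the comparison. Compound 2 (`COc1ccccc1-c1cnc(OC)n1C`) is the smaller partner, bearing a methoxy group where compound 1 has a longer chain. In this assay compound 2 gives > 100000 nM, which is a limit of the assay rather than a measured number. That places compound 2 at the limit of > 100000 nM in this assay, at which 1 of the 2 values shown sits. Compound 3 (`C=CCCCCOc1ncc(-c2ccccc2OC)n1C`) has not yet been measured; it differs from compound 2 by pent-4-en-1-yl in place of hydrogen on a saturated chain carbon bound to an oxygen on an aromatic ring. Going by the values given here, no step between two measured compounds is available to guide the expectation, so the size of this change is uncertain; the step of an at least 3.3-fold lower number from compound 2 to compound 3 (0.52 log units; beyond the scatter) is expected to move toward stronger inhibition, out of the region where only a limit is reported. Compound 3 is therefore estimated at 30000 nM, most likely between 5000 nM and 150000 nM.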

Compound 3, half-maximal inhibitory concentration: 9000 nM
Compound 3: the middle estimate sits 3.3-fold (0.52 log units) above what was measured; the measured number falls inside the stated range.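

In this assay, putting pent-4-en-1-yl in place of hydrogen on a saturated chain carbon bound to an oxygen on an aromatic ring gives an at least 11-fold lower number from compound 2 to compound 3 (1.04 log units; beyond the scatter), so this position responds to the change, and the response is toward stronger inhibition. With its (hex-5-en-1-yl)oxy group, compound 3 gives 9000 nM, the only single number among the compounds shown. The true size of the step stays unknown, because one end of it is only a limit: the limit of > 100000 nM in this assay, at which 1 of the 3 values shown sits.

The compounds shown do not separate the effect of the chain's length from that of its double bond. Going by these compounds, how a saturated hexyl chain, a longer chain, or a chain ending in an amine or a carboxylic acid would behave also remains open.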